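Methoxy for cyano on the aryl urea of compound 2

The compounds below may be only part of what the source reports. "The series", "measured", "known", "first", "only" and "open" are said of these compounds alone.

Compound 2 `CNc1nccc(N2CC[C@H](NC(=O)Nc3cccc(C#N)c3)C2)n1` gives 94.4% in an ADME assay on a cell-free system (plasma, Homo sapiens) for protein binding, the highest unbound fraction among the three measured compounds. For the measured compounds named here, compound 1 `Nc1nccc(N2CC[C@H](NC(=O)Nc3ccc(Cl)c(C(F)(F)F)c3)C2)n1` gives 99.5% and compound 3 `O=C(Nc1ccc(Cl)c(C(F)(F)F)c1)N[C@H]1CCN(c2ccncn2)C1` gives 99.3%; the only single-point step between measured compounds, a 1.4-fold higher unbound fraction from compound 1 to compound 3 (0.15 log units; within the scatter), concerns the amino group on the shared core and leaves the aryl urea untouched. Compound 4 `CNc1nccc(N2CC[C@H](NC(=O)Nc3cccc(OC)c3)C2)n1` differs from compound 2 by methoxy in place of cyano on an aromatic carbon. Going by the values given here, no measured step bears on this exchange, so the expectation rests on compound 2 alone, with compounds 1 and 3 marking the high-binding end of the series. A modest step toward higher binding is expected for compound 4, a 1.4-fold lower unbound fraction from compound 2 to compound 4 (0.15 log units; within the scatter). Compound 4 is estimated at 96%, within a range of 91% to 98.5%.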

Compound 4, plasma protein binding in the Homo sapiens assay: 96.7%
Compound 4: the middle estimate sits 1.2-fold (0.08 log units) (unbound fraction) above what was measured, within the range that was stated.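

For the compounds shown here, in the Homo sapiens assay the exchange at this aromatic carbon gives a 1.7-fold lower unbound fraction from compound 2 to compound 4 (0.23 log units; within the scatter) and is the first step read on the aryl urea rather than on the amino group of the shared core. In a physicochemical assay for solubility, measured as kinetic solubility (on this read-out lower numbers stand for lower solubility and higher numbers for higher solubility), compound 2 gives 95700 nM and compound 4 gives 116000 nM with a 1.2-fold higher number from compound 2 to compound 4 (0.08 log units; within the scatter) so neither read-out separates methoxy from cyano here. Nothing available gives a reason for these results. As far as these compounds go, whether an amine or a carboxylic acid at this position would move either read-out beyond the scatter stays open, as does whether methoxy for cyano reads the same on the aryl urea of compound 1.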